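The compounds below may be only part of what the source reports. "The series", "measured", "known", "first", "only" and "open" are said of these compounds alone.

Compound 1 `O=c1c2ccccc2[se]n1-c1nnc(-c2ccccc2Cl)s1` gives 10100 nM in a functional assay on A549 cells (Homo sapiens) for antiproliferative activity, read by CCK-8 assay, with a stated time of 48 h; on this read-out lower numbers stand for stronger inhibition and higher numbers for weaker inhibition; compound 2 `Cc1ccccc1-c1nnc(-n2[se]c3ccccc3c2=O)s1` gives 18600 nM; compound 3 `O=c1c2ccccc2[se]n1-c1nnc(-c2ccccc2[N+](=O)[O-])s1` gives 11400 nM.

On these three numbers compound 3 stands second highest, with compound 1 nearest a 1.1-fold higher number from compound 1 to compound 3 (0.05 log units; within the scatter) and compound 2 furthest a 1.6-fold lower number from compound 2 to compound 3 (0.21 log units; within the scatter). The step to compound 4 `COc1ccccc1-c1nnc(-n2[se]c3ccccc3c2=O)s1` is methoxy in place of nitro on an aromatic carbon. Going by the values given here, the steps that bear on it are the other swaps at this position: a 1.8-fold higher number from compound 1 to compound 2 (0.27 log units; within the scatter) and a 1.1-fold higher number from compound 1 to compound 3 (0.05 log units; within the scatter), both within the scatter. A fourth group at the same place is therefore expected to give no step beyond the scatter in this assay, in either direction, as expressed by a 1.1-fold higher number from compound 3 to compound 4 (0.06 log units; within the scatter). Compound 4 is estimated at 13000 nM, with a range from 6000 nM to 28000 nM.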

Compound 4, half-maximal inhibitory concentration: 3120 nM
The estimate for compound 4 lay 4.2-fold (0.62 log units) above the measured number; the measured number lies below the stated range.
By their numbers in this assay, from the lowest: compound 4; then compounds 1, 3 and 2 (each within the scatter of the next).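

Going by these compounds alone, until now every swap at this position stayed within the scatter, and methoxy is the first group to move the number beyond it in this assay, with a 3.7-fold lower number from compound 3 to compound 4 (0.56 log units; beyond the scatter), a 6.0-fold lower number from compound 2 to compound 4 (0.78 log units; beyond the scatter) and a 3.2-fold lower number from compound 1 to compound 4 (0.51 log units; beyond the scatter). The position therefore does respond to the group it carries, and of the four groups only methoxy stands apart from the others. Nothing measured here accounts for this step. From the compounds shown here alone, what remains open is whether the lower number is particular to methoxy, since a hydroxyl, an ethoxy or an amine at the same place would be needed to tell. Going by these compounds, whether the step holds on other cell lines also stays open.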